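The source may report more compounds than this note shows. Statements on the series, on what has been measured and on what is new or still open speak of the compounds shown alone.

Measured compounds in the series:
- compound 1 `CC1CCN(c2c(S(=O)(=O)c3ccccc3)cnc3ccccc23)CC1` gives 89.2% in an assay on isolated protein for displacement of a labelled ligand from metabotropic glutamate receptor 5 (Homo sapiens), with a stated time of 60 min, tested at 1 uM; a higher number here means more inhibition at the concentration tested (going by the name of the read-out), a lower number less inhibition
- compound 3 `CC1CCN(c2c(S(=O)(=O)c3ccccc3)cnc3cc(F)ccc23)CC1` gives 87% in this assay
- compound 2 `NS(=O)(=O)N1CCN(c2c(S(=O)(=O)c3cc(F)cc(F)c3)cnc3cc(F)ccc23)CC1` gives 6.4% in this assay

Compounds 1 and 3 share one core and differ by hydrogen in place of fluoro on an aromatic carbon; the step of a number 2.2 percentage points higher from compound 3 to compound 1 (within the scatter), so the two read as equivalent. Compound 2 sits far below both; the difference between its core and the core of compound 3 is not broken down here.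

Compound 4 `NS(=O)(=O)N1CCN(c2c(S(=O)(=O)c3cccc(F)c3)cnc3cc(F)ccc23)CC1` is not yet measured. It differs from compound 2 by hydrogen in place of fluoro on an aromatic carbon. This is the same kind of change as from compound 3 to compound 1, though not at the same place: in compound 3 the fluoro sits on a ring that is part of a fused or bridged system of two rings, meta to a fused ring and para to a fused ring, whereas in compound 2 it sits on a ring of carbon only, meta to a fluoro group and meta to a large group.

For the measured compounds named here, only one step of this kind is known, and it stayed within the scatter. On that basis compound 4 is expected to stay close to compound 2, with an estimated step of a number 3.6 percentage points higher from compound 2 to compound 4 (within the scatter) in this assay. The estimate for compound 4 is 10%, expected between 0% and 30%.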

Compound 4, a percentage reported as inhibition, at one concentration (the size of the read-out at that concentration, not a potency): 1.9%
Estimate against measurement, compound 4: 8.1 percentage points above; low and high end bracket the measured number.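

In this assay, hydrogen in place of fluoro on the ring of carbon only gives a number 4.5 percentage points lower from compound 2 to compound 4 (within the scatter), so the change from 3,5-difluorophenyl to 3-fluorophenyl leaves this pair at a low level of inhibition. Set beside the earlier step, the same exchange shows no detectable difference between the two cores: the same change on two cores in this assay, a number 2.2 percentage points higher (within the scatter) from compound 3 to compound 1 and a number 4.5 percentage points lower (within the scatter) from compound 2 to compound 4, 6.7 percentage points apart, within the scatter of two such steps This does not show that the change is neutral in general, as only two pairs are at hand, the fluoro sits at a different place in each, and a read-out at one concentration is not a potency, so a shift could go unseen in the pair of compound 3, which gives 87%, or in the pair of compound 2, which gives 6.4%.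

For the compounds shown here, still open is which part of the structure separates the high pair from the low pair, as no single-place step links them. Also open, on these data alone, is how a methoxy group, a nitrile or an amine in place of this fluoro would read.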